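A few compounds are considered here, and "the series" means these few. Any claim that something is new, unique, unknown or untested is made for them only; others in the source may bear on it.

Measured in an ADME assay on L02 cells (Homo sapiens) for inhibition, read by CCK-8 assay, with a stated time of 48 h; on this read-out higher numbers stand for weaker inhibition of growth and lower numbers for stronger inhibition of growth:
Compound 1 `Cc1ccccc1Nc1nc(Nc2ccc(N3CCN(C)CC3)cn2)ncc1Cl`: 5980 nM
Compound 2 `CN1CCN(c2ccc(Nc3ncc(Cl)c(Nc4ccccc4)n3)nc2)CC1`: 7990 nM
Compound 3 `CCc1ccc(Nc2nc(Nc3ccc(N4CCN(C)CC4)cn3)ncc2Cl)cc1`: 12100 nM

Compound 3 sits at the high end of these three numbers, with a 1.5-fold higher number from compound 2 to compound 3 (0.18 log units; within the scatter) and a 2.0-fold higher number from compound 1 to compound 3 (0.31 log units; beyond the scatter). Compound 4 `COc1ccc(Nc2nc(Nc3ccc(N4CCN(C)CC4)cn3)ncc2Cl)cc1` has methoxy in place of ethyl on an aromatic carbon, para to a large group (methoxy in place of ethyl on an aromatic carbon). For the measured compounds named here, no measured step makes this exchange directly. The nearest evidence is the step that introduced the ethyl of compound 3 in place of hydrogen, which stayed within the scatter. The step with hydrogen in place of methyl on an aromatic carbon is a 1.3-fold higher number from compound 1 to compound 2 (0.13 log units; within the scatter), and it also stayed within the scatter. Going by the values given here, the only step beyond the scatter is modest and involves a different exchange. On these three compounds, no step beyond the scatter is expected in this assay. The expected change is small: a 1.2-fold lower number from compound 3 to compound 4 (0.08 log units; within the scatter). The estimated value for compound 4 is 10000 nM, with an expected range of 5500 nM to 18000 nM.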

Compound 4, concentration for 50% growth inhibition: 3150 nM
Estimate against measurement, compound 4: 3.2-fold (0.50 log units) above; measured number outside the range, below it.
By their numbers in this assay, from the lowest: compounds 4, 1, 2 and 3 (each within the scatter of the next, the first and the last beyond it).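

In this assay, for the compounds shown here, the aromatic carbon para to a large group responds to the group it carries: methoxy in place of ethyl, both of 2 heavy atoms, gives a 3.8-fold lower number from compound 3 to compound 4 (0.58 log units; beyond the scatter) and is the largest step so far. Ethyl in place of hydrogen had stayed within the scatter, whereas methoxy in place of hydrogen gives a 2.5-fold lower number from compound 2 to compound 4 (0.40 log units; beyond the scatter) and so separates from hydrogen at this carbon. The 4-methoxyphenyl in place of 2-methylphenyl gives a 1.9-fold lower number from compound 1 to compound 4 (0.28 log units; within the scatter) and so does not separate these two groups on the same nitrogen.

The compounds shown leave open whether the oxygen or the methoxy group as a whole carries this step, and how a hydroxyl, an amine or a longer chain such as ethoxy would read at this carbon. Nothing available explains these steps.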